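A few compounds are considered here, and "the series" means these few. Any claim that something is new, unique, unknown or untested is made for them only; others in the source may bear on it.

In a functional assay on A549 cells (Homo sapiens) for inhibition, read by MTT assay, with a stated time of 72 h (a lower number here means a stronger inhibitor, a higher number a weaker inhibitor), two compounds sharing one core have been measured so far: compound 1 `CC(C)(C)n1cc2c(n1)C(=O)CC1(CCN(C(=O)c3cc(-c4ccccc4)nc4ccccc34)CC1)O2` gives 1940 nM, and compound 2 `CC(C)(C)n1cc2c(n1)C(=O)CC1(CCN(C(=O)c3cc(-c4ccccn4)nc4ccccc34)CC1)O2` gives 7720 nM, the higher of the two numbers. Compound 3 `CC(C)(C)n1cc2c(n1)C(=O)CC1(CCN(C(=O)c3cc(Cl)nc4ccccc34)CC1)O2` differs from compound 2 by a single change, chloro in place of pyridin-2-yl on an aromatic carbon, next to the ring nitrogen. Among the compounds with values here, only one measured step bears on this place, a 4.0-fold higher number from compound 1 to compound 2 (0.60 log units; beyond the scatter), a modest step with pyridin-2-yl in place of phenyl. Within the data shown here, that step exchanges one aromatic ring for another, whereas here the ring leaves altogether, and no chloro compound has been measured. It is therefore a weak guide, and no step beyond the scatter is expected in this assay, in either direction. The expected step is a 1.1-fold lower number from compound 2 to compound 3 (0.04 log units; within the scatter). For compound 3 the estimated value is 7000 nM, within an expected range of 2000 nM to 25000 nM.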

Compound 3, half-maximal inhibitory concentration: 7170 nM
Compound 3: middle estimate off by 1.0-fold (0.01 log units), on the low side; the range from low to high includes it.
By their numbers in this assay, from the lowest: compound 1; then compounds 3 and 2 (each within the scatter of the next).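

In this assay, chloro in place of the whole pyridin-2-yl ring gives a 1.1-fold lower number from compound 2 to compound 3 (0.03 log units; within the scatter), so at this place, next to the ring nitrogen, an aromatic ring is not needed to keep the number where pyridin-2-yl holds it. Chloro in place of phenyl gives a 3.7-fold higher number from compound 1 to compound 3 (0.57 log units; beyond the scatter), which leaves phenyl alone apart from the other two groups at this position, with the lowest number of the three compounds. Nothing given here accounts for why phenyl differs from pyridin-2-yl and chloro.

The compounds shown leave open how an amine, a methoxy group or a plain hydrogen at this place would read. They also leave open whether a phenyl ring carrying a fluoro or methoxy group would fall below compound 1 or rise toward compound 2 and compound 3.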